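The source may report more compounds than this note shows. Statements on the series, on what has been measured and on what is new or still open speak of the compounds shown alone.

For the measured compounds named here, compound 2 `O=C(NC(=S)Nc1ccc(Br)c(C(F)(F)F)c1)c1ccccc1` stands at the low end of the three numbers so far in an assay for inhibition of epoxide hydrolase 1 (Homo sapiens), read by fluorescence, using microsomes (on this read-out higher numbers stand for weaker inhibition and lower numbers for stronger inhibition), giving 1170 nM. Compound 1 `CC(=O)NC(=S)Nc1ccc(Br)cc1` gives 1640 nM in this assay, within the scatter of compound 2, while compound 3 `O=C(NC(=S)Nc1ccc(Br)cc1)c1ccccc1` gives 3440 nM, beyond it. Compound 4 `CC(=O)NC(=S)Nc1ccc(Br)c(C(F)(F)F)c1` is not yet measured; it differs from compound 2 by methyl in place of phenyl on a carbonyl carbon. The reverse of this change has been seen once: a 2.1-fold higher number from compound 1 to compound 3 (0.32 log units; beyond the scatter). The other step, a 2.9-fold higher number from compound 2 to compound 3 (0.47 log units; beyond the scatter), concerns the trifluoromethyl and does not bear on this change. Running the carbonyl step backwards, a modest move to a lower number is expected in this assay, namely a 2.0-fold lower number from compound 2 to compound 4 (0.29 log units; within the scatter). Compound 4 is therefore estimated at 600 nM, with a range from 250 nM to 1500 nM.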

Compound 4, half-maximal inhibitory concentration: 1390 nM
For compound 4 the middle estimate is 2.3-fold (0.36 log units) below the measured one; measured number inside the range.
By their numbers in this assay, from the lowest: compounds 2, 4 and 1 (each within the scatter of the next); then compound 3.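

Methyl in place of phenyl on a carbonyl carbon now gives a 1.2-fold higher number from compound 2 to compound 4 (0.07 log units; within the scatter), so with trifluoromethyl on the aromatic ring, this change shows no step beyond the scatter, though its two readings do not separate: the same change on two cores in this assay, a 2.1-fold higher number (0.32 log units; beyond the scatter) from compound 1 to compound 3 and a 1.2-fold lower number (0.07 log units; within the scatter) from compound 4 to compound 2, 2.5-fold (0.40 log units) apart, within the scatter of two such steps

Trifluoromethyl in place of hydrogen on an aromatic carbon, earlier seen only with phenyl on the carbonyl carbon, gives a 1.2-fold lower number from compound 1 to compound 4 (0.07 log units; within the scatter) with methyl there, and these two readings do not separate either: the same change on two cores in this assay, a 2.9-fold higher number (0.47 log units; beyond the scatter) from compound 2 to compound 3 and a 1.2-fold higher number (0.07 log units; within the scatter) from compound 4 to compound 1, 2.5-fold (0.40 log units) apart, within the scatter of two such steps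

Still open, from the compounds shown here alone, is whether a longer chain or an amine on the carbonyl carbon, or a nitrile in place of trifluoromethyl, would give a number beyond the scatter of compound 2, compound 4 and compound 1.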